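The source may hold more compounds than are shown below. What is called first, only, known or untested is meant among the compounds shown, and "the series" means these compounds.

Compound 1 `CCc1cc2ccccc2nc1-c1cc(-c2ccc(F)cc2)no1` gives in a functional assay on COLO 205 cells (Homo sapiens) for inhibition, read by MTT assay, with a stated time of 24 h (on this read-out higher numbers stand for weaker inhibition and lower numbers for stronger inhibition), a value that is only a limit of the assay, > 100000 nM.
Compound 2 `CCCc1cc2ccccc2nc1-c1cc(-c2ccc(F)cc2)no1` gives in this assay 50300 nM.
Compound 3 `CCCCc1cc2ccccc2nc1-c1cc(-c2ccc(C(F)(F)F)cc2)no1` gives in this assay 11900 nM.

From compound 1 to compound 2 the change is methyl in place of hydrogen on a saturated chain carbon, two bonds along the chain from an aromatic carbon, and the step is an at least 1.9-fold lower number from compound 1 to compound 2 (0.29 log units; that floor lies within the scatter); that compound 1 sits at a limit of > 100000 nM in this assay, at which 1 of the 3 values shown sits, means the true size of this step is not known. Compound 3 carries a longer chain and a trifluoromethyl group; the difference between its core and the core of compound 1 is not broken down here. Compound 4 `CCCCCc1cc2ccccc2nc1-c1cc(-c2ccc(C(F)(F)F)cc2)no1`, not yet measured, differs from compound 3 by methyl in place of hydrogen on a saturated chain carbon, four bonds along the chain from an aromatic carbon, the same kind of change as from compound 1 to compound 2, but placed four bonds rather than two bonds along the chain. On the step from compound 1 to compound 2, an at least 1.9-fold lower number from compound 1 to compound 2 (0.29 log units; that floor lies within the scatter), a modest gain is expected for compound 4, estimated as a 1.7-fold lower number from compound 3 to compound 4 (0.23 log units; within the scatter). Compound 4 is therefore expected to give about 7000 nM, within 3000 nM to 20000 nM.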

Compound 4, half-maximal inhibitory concentration: 24500 nM
For compound 4 the middle estimate is 3.5-fold (0.54 log units) below the measured one, and the stated range ends below it.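

Lengthening the chain by one methyl gives a 2.1-fold higher number from compound 3 to compound 4 (0.31 log units; beyond the scatter) in this assay. This change therefore does not carry over unchanged from one core to the other, as the two steps run in opposite directions: the same change on two cores in this assay, an at least 1.9-fold lower number (0.29 log units; that floor lies within the scatter) from compound 1 to compound 2 and a 2.1-fold higher number (0.31 log units; beyond the scatter) from compound 3 to compound 4, at least 4.0-fold (0.61 log units) apart, beyond the scatter of two such steps. On these data alone, compound 1 sits at a limit of the assay, so the true size of the earlier step stays unknown, and these compounds cannot separate the effect of the core from that of the place on the chain, two bonds along or four bonds along: the limit of > 100000 nM in this assay, at which 1 of the 4 values shown sits.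

Still open, as far as these compounds go, is how a longer chain, or a chain ending in an amine or a carboxylic acid, would fare on the core of compound 3. Also open, from the compounds shown here alone, is whether a nitrile in place of the trifluoromethyl group would alter the step.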